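This account rests on a few compounds, and the source may have more. Where it says the series, first, only, none or still open, it means among the compounds named here.

Compound 1, `N#Cc1cccc(-c2nc(N)c3cc(CN4CCC(F)CC4)sc3n2)c1`, and compound 3, `Nc1nc(-c2cccc(C(F)(F)F)c2)nc2sc(CN3CCC(F)CC3)cc12`, share a core with compound 2, `N#Cc1ccc(-c2nc(N)c3cc(CN4CCC(F)CC4)sc3n2)cc1`, and with the not yet measured compound 4, `Nc1nc(-c2ccc(C(F)(F)F)cc2)nc2sc(CN3CCC(F)CC3)cc12`. In an assay on CHO-K1 cells for antagonist activity at adenosine receptor A1 (Homo sapiens), read by a beta-galactosidase reporter, with stated times of 15 min and 6 h (a higher number here means a weaker inhibitor, a lower number a stronger inhibitor), compound 1 gives 2950 nM, compound 2 gives 8430 nM and compound 3 gives 3030 nM. Compound 2 has the highest of the three numbers; its nearest neighbour is compound 3 and the furthest is compound 1.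

The cores of compound 1 and compound 2 differ as 4-cyanophenyl in place of 3-cyanophenyl on an aromatic carbon, and the step of a 2.9-fold higher number from compound 1 to compound 2 (0.46 log units; beyond the scatter) in this assay is modest but beyond the scatter. The change from compound 1 to compound 3 is trifluoromethyl in place of cyano on an aromatic carbon, and it left the number essentially unchanged, as shown by a 1.0-fold higher number from compound 1 to compound 3 (0.01 log units; within the scatter). The change from compound 2 to compound 4 is trifluoromethyl in place of cyano on an aromatic carbon; it is the same kind of change, but the place differs: in compound 1 the group sits meta to a large group, in compound 2 it sits para to a large group, so the two changes are not the same.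

The expectation for compound 4 rests on a single precedent. Because a 1.0-fold higher number from compound 1 to compound 3 (0.01 log units; within the scatter) lay within the scatter, the step from compound 2 to compound 4 in this assay is expected to be about as small, a 1.1-fold lower number from compound 2 to compound 4 (0.02 log units; within the scatter), with the uncertainty of transferring it to a different place. Compound 4 is therefore estimated at 8000 nM in this assay, with a range from 3500 nM to 18000 nM.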

Compound 4, inhibition constant: 3560 nM
Beside the measured number, compound 4's estimate is 2.2-fold (0.35 log units) above it, and the stated range covers the measured number.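

In this assay, trifluoromethyl in place of cyano, para to a large group, gives a 2.4-fold lower number from compound 2 to compound 4 (0.37 log units; beyond the scatter), so on this core the change stands out from the scatter as a modest step, while on the core of compound 1 the same change gave no step beyond the scatter. Set side by side, the two steps cannot be told apart, so these results give no ground for saying that the change behaves differently on the two cores: the same change on two cores in this assay, a 1.0-fold higher number (0.01 log units; within the scatter) from compound 1 to compound 3 and a 2.4-fold lower number (0.37 log units; beyond the scatter) from compound 2 to compound 4, 2.4-fold (0.39 log units) apart, within the scatter of two such steps This does not show that the change carries over with a fixed size, for it rests on two pairs of compounds only, and it gives no explanation of why one step taken alone lies beyond the scatter and the other within it.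

The compounds shown leave open whether the same reading would hold for other groups on that aromatic carbon, such as a chlorine, a methoxy group, an amine or a carboxylic acid. They also leave open how trifluoromethyl in place of cyano would read on a core that differs elsewhere, for instance with a longer chain in place of the fluorinated amine side chain.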